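The source may hold more compounds than are shown below. What is called first, only, known or untested is meant among the compounds shown, and "the series" means these compounds.

Measured so far in a functional assay on MV4-11 cells (Homo sapiens) for inhibition, read by resazurin assay, with a stated time of 72 h; a higher number here means a weaker inhibitor of growth, a lower number a stronger inhibitor of growth:
- compound 1 `COc1ccc(Nc2nccc(-c3sc(SCc4cccnc4)nc3C)n2)c(OC)c1`: 270 nM
- compound 2 `COc1ccc(Nc2nccc(-c3sc(OC(C)C)nc3C)n2)c(OC)c1`: 8690 nM

Of these two numbers, the higher belongs to compound 2, at 8690 nM, so it is the weaker inhibitor of growth here. Compound 3 `CCOc1nc(C)c(-c2ccnc(Nc3ccc(OC)cc3OC)n2)s1` is not yet measured. Its structure departs from compound 2 in one place: hydrogen in place of methyl on a saturated chain carbon bound to an oxygen on an aromatic ring and a saturated chain carbon. This is hydrogen in place of methyl, which turns isopropoxy to ethoxy.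

Among the measured compounds shown here, only one measured step bears on this: a 32-fold higher number from compound 1 to compound 2 (1.51 log units; beyond the scatter). For the measured compounds named here, that step exchanged a whole ((pyridin-3-yl)methyl)sulfanyl for isopropoxy, a far bigger change than this one, and no measured step shows what trimming a single methyl does. A step within the scatter is therefore expected in this assay, with no firm direction. The estimated step is a 1.2-fold lower number from compound 2 to compound 3 (0.09 log units; within the scatter). For compound 3 the expected value is 7000 nM, with an estimated range of 3000 nM to 16000 nM.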

Compound 3, concentration for 50% growth inhibition: 3890 nM
Compound 3: middle estimate off by 1.8-fold (0.26 log units), on the high side, and the stated range covers the measured number.
By their numbers in this assay, from the lowest: compound 1; then compound 3; then compound 2.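

Removing a methyl to turn isopropoxy into ethoxy is a small edit, yet in this assay it produces a modest shift beyond the usual scatter (a 2.2-fold lower number from compound 2 to compound 3 (0.35 log units; beyond the scatter)). This position therefore responds to a change as small as one methyl, and of these two groups, ethoxy gives the stronger inhibitor of growth. Ethoxy still falls well short of ((pyridin-3-yl)methyl)sulfanyl (a 14-fold higher number from compound 1 to compound 3 (1.16 log units; beyond the scatter)), and no available evidence explains either difference.

Going by these compounds, two alkoxy groups cannot establish a trend, so whether methoxy would continue this shift remains open. It is also unclear whether the advantage of compound 1 depends on its sulfanyl link or its pyridin-3-yl part, a question that (pyridin-3-yl)methoxy and benzylsulfanyl groups could help separate.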